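Methylene insertion at the naphthyl sulfonamide: expectation for compound 4

A few compounds are considered here, and "the series" means these few. Any claim that something is new, unique, unknown or untested is made for them only; others in the source may bear on it.

Within the shared core, compound 1 `CCCCCCCCCCCCCCCC(=O)NCCC(=O)Nc1ccc(S(=O)(=O)N[C@@H](CCSC)C(=O)OC)cc1` gives 28% in an in vitro assay on Sf9 cells for inhibition of CAAX prenyl protease 2 (Homo sapiens), tested at 10 uM (a lower number here means less inhibition, a higher number more inhibition at the concentration tested (going by the name of the read-out)), and compound 2 `CCCCCCCCCCCCCCCC(=O)NCCC(=O)Nc1cccc(S(=O)(=O)Nc2cccc(C)c2C)c1` gives 18%. Compound 3 `CCCCCCCCCCCCCCCC(=O)NCCC(=O)Nc1cccc(S(=O)(=O)Nc2cccc3ccccc23)c1` returns only the assay limit, < 5%, so no number is known for it. The step of a number at least 13 percentage points lower from compound 2 to compound 3 (beyond the scatter) places compound 3 at the low end of the three values, sitting at the limit of < 5% in this assay, at which 1 of the 3 values shown sits.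

Compound 4 `CCCCCCCCCCCCCCCC(=O)NCCC(=O)Nc1cccc(S(=O)(=O)NCc2cccc3ccccc23)c1` differs from compound 3 by (naphthalen-1-yl)methyl in place of naphthalen-1-yl on a sulfonamide nitrogen. Among the measured compounds shown here, no measured step covers this change; the only step in hand, a number at least 13 percentage points lower from compound 2 to compound 3 (beyond the scatter), concerns the aryl group itself and not the added methylene. Compound 3 being at the limit, compound 4 is expected to remain close to it, with an estimated 7% in the range 0% to 20%. The expected step of a number at least 2 percentage points higher from compound 3 to compound 4 (that floor lies within the scatter) is not expected to exceed the scatter.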

Compound 4, a percentage reported as inhibition, at one concentration (the size of the read-out at that concentration, not a potency): 20%
Estimate against measurement, compound 4: 13 percentage points below, and the stated range covers the measured number.
By their numbers in this assay, from the lowest: compounds 2, 4 and 1 (each within the scatter of the next). At a limit, below all of these: compound 3.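

In this assay, (naphthalen-1-yl)methyl in place of naphthalen-1-yl on the sulfonamide nitrogen brings back a measurable inhibition, so the naphthalene rings alone do not hold the read-out at the limit: a number at least 15 percentage points higher from compound 3 to compound 4 (beyond the scatter). With the added methylene, the naphthalene compound is level with the 2,3-dimethylphenyl compound: a number 2 percentage points higher from compound 2 to compound 4 (within the scatter). Compound 3 remains a limit, so the first step has only a floor: the limit of < 5% in this assay, at which 1 of the 4 values shown sits.

Still open, as far as these compounds go, is whether a longer chain to the naphthalene rings on the sulfonamide nitrogen raises the read-out further. Also open, from the compounds shown here alone, is how a carboxylic acid on that nitrogen's substituent would read.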